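The source may hold more compounds than are shown below. What is called first, only, known or untested is meant among the compounds shown, and "the series" means these compounds.

Measured in a functional assay on Jurkat cells (Homo sapiens); on this read-out higher numbers stand for weaker inhibition and lower numbers for stronger inhibition:
compound 1 `CC(C)[C@H](NC(=O)COc1cccc2ccccc12)C(=O)N[C@@H](CC(=O)O)C(=O)COc1ccc2ccccc2c1`: > 100000 nM
compound 2 `CC(=O)Nc1cccc(OCC(=O)[C@H](CC(=O)O)NC(=O)[C@@H](NC(=O)COc2cccc3ccccc23)C(C)C)c1`: > 100000 nM

Compound 2 gives > 100000 nM, which is a limit and not a number. Compound 1 also gives a limit, so both compounds stand at the limit of > 100000 nM in this assay, at which 2 of the 2 values shown sit.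

Compound 3 `CC(C)[C@H](NC(=O)COc1cccc2ccccc12)C(=O)N[C@@H](CC(=O)O)C(=O)COc1ccccc1F` keeps the core of compound 2 and changes one group: 2-fluorophenyl in place of 3-acetamidophenyl on an oxygen on a saturated carbon. In words, 2-fluorophenyl takes the place of 3-acetamidophenyl on an oxygen on a saturated carbon. For the measured compounds named here, the one measured step at this place is a step that the two limits leave unreadable from compound 1 to compound 2. It gives no size that can be carried over, so the expectation for this assay is only loosely held. A further result at the limit remains quite likely. If a number is obtained, it is expected to show stronger inhibition. The expected step is an at least 3.3-fold lower number from compound 2 to compound 3 (0.52 log units; beyond the scatter). The estimate for compound 3 is 30000 nM, expected within 1000 nM to 100000 nM.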

Compound 3, half-maximal inhibitory concentration: > 100000 nM
Compound 3 was reported as a limit (the forecaster's own chance of this, stated with the estimate: 50%); middle value at least 3.3-fold (0.52 log units) from the limit.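

In this assay compound 3 gives > 100000 nM, which is a limit and not a number. The steps to compound 3 from compound 1 and compound 2 cannot be read: the limit of > 100000 nM in this assay, at which 3 of the 3 values shown sit. The compounds shown leave open whether any of these groups on the oxygen gives measurable inhibition.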